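Swapping Nitro for Chloro in a Small Series

This account rests on a few compounds, and the source may have more. Where it says the series, first, only, none or still open, it means among the compounds named here.

Measured so far in a functional assay on MCF7 cells (Homo sapiens) for inhibition, read by MTT assay, with a stated time of 72 h; on this read-out higher numbers stand for weaker inhibition and lower numbers for stronger inhibition:
- Compound 1 `Cc1cccc(-n2c(-c3coc4cc(C)c(Cl)cc4c3=O)nc(-c3ccccc3)c2-c2ccccc2)c1` gives 12500 nM
- Compound 2 `Cc1cc2occ(-c3nc(-c4ccccc4)c(-c4ccccc4)n3-c3ccc(Cl)cc3)c(=O)c2cc1Cl` gives 12500 nM
- Compound 3 `Cc1cc2occ(-c3nc(-c4ccccc4)c(-c4ccccc4)n3-c3cccc([N+](=O)[O-])c3)c(=O)c2cc1Cl` gives 1560 nM

Compound 3 has the lowest number of the three, which here means the strongest inhibition, and its distance to each of the other two lies beyond the scatter. The next compound, compound 4 `Cc1cc2occ(-c3nc(-c4ccccc4)c(-c4ccccc4)n3-c3cccc(Cl)c3)c(=O)c2cc1Cl`, changes a single group: chloro in place of nitro on an aromatic carbon. In words, this is chloro in place of nitro on an aromatic carbon, turning 3-nitrophenyl into 3-chlorophenyl.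

Among the measured compounds shown here, three measured steps bear on this change. Nitro in place of methyl gave an 8.0-fold lower number from compound 1 to compound 3 (0.90 log units; beyond the scatter). The change from 4-chlorophenyl to 3-nitrophenyl gave an 8.0-fold lower number from compound 2 to compound 3 (0.90 log units; beyond the scatter). The two rings without nitro showed no change at the digits printed from compound 1 to compound 2 (within the scatter). In this small set, then, both compounds without nitro sit at the higher number, and neither goes against that pattern. For the measured compounds named here, no measured compound carries 3-chlorophenyl, so this reading remains indirect. In this assay a step toward a higher number is therefore expected, close in size to those two nitro steps or somewhat smaller: a 6.4-fold higher number from compound 3 to compound 4 (0.81 log units; beyond the scatter). Compound 4 is estimated at 10000 nM, with an expected range of 3500 nM to 25000 nM.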

Compound 4, half-maximal inhibitory concentration: 6250 nM
Estimate against measurement, compound 4: 1.6-fold (0.20 log units) above, and the stated range covers the measured number.
By their numbers in this assay, from the lowest: compound 3; then compounds 4, 1 and 2 (each within the scatter of the next).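

In this assay, replacing nitro directly with chloro gives a 4.0-fold higher number from compound 3 to compound 4 (0.60 log units; beyond the scatter), so the gap seen earlier now appears in a pair that differs only in the group on this one aromatic carbon. The other two comparisons place compound 4 with the compounds lacking nitro: 3-chlorophenyl in place of 4-chlorophenyl gives a 2.0-fold lower number from compound 2 to compound 4 (0.30 log units; within the scatter), and chloro in place of methyl gives a 2.0-fold lower number from compound 1 to compound 4 (0.30 log units; within the scatter). Among these four compounds, compound 3 is the strongest inhibitor and the only one carrying nitro, and no compound goes against that pattern, while this assay does not separate chloro from methyl at this place or 3-chlorophenyl from 4-chlorophenyl.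

Nothing shown here explains why nitro and chloro differ at this position. From the compounds shown here alone, it also remains open whether an amine, a nitrile or a carboxylic acid on the same aromatic carbon would give a number near that of compound 3 or near those of the other three compounds, and whether 4-nitrophenyl would match 3-nitrophenyl.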